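The source may report more compounds than this note shows. Statements on the series, on what has been measured and on what is new or still open speak of the compounds shown alone.

Compound 1 `Nc1scc(-c2cccc(F)c2)c1C(=O)c1ccc(Cl)cc1`: 90%
Compound 2 `Nc1scc(-c2ccc(F)cc2)c1C(=O)c1ccc(Cl)cc1`: 61%
Compound 3 `Nc1scc(-c2cccc(Br)c2)c1C(=O)c1ccc(Cl)cc1`: 69%

These three compounds were measured in a functional assay on CHO cells for agonist activity at adenosine receptor A1 (Homo sapiens), read by fluorescence and ERK phosphorylation, with stated times of 30 min and 1.5 h, tested at 10 uM; a lower number here means a weaker effect, a higher number a stronger effect of the compound at the concentration tested. Compound 2 gives the lowest of the three numbers, but its gap to compound 3, a number 8 percentage points higher from compound 2 to compound 3 (within the scatter), lies within the scatter, so the two cannot be ranked; only compound 1 stands clearly apart, with a number 29 percentage points lower from compound 1 to compound 2 (beyond the scatter). The unmeasured compound 4 `Nc1scc(-c2ccc([N+](=O)[O-])cc2)c1C(=O)c1ccc(Cl)cc1` differs from compound 2 by a single change: nitro in place of fluoro on an aromatic carbon. Among the measured compounds shown here, no measured step swaps fluoro for nitro. The nearest guide is the exchange of one halogen for another on the same pendant phenyl, a number 21 percentage points lower from compound 1 to compound 3 (beyond the scatter), a modest drop; the move of the fluoro between positions on that ring, a number 29 percentage points lower from compound 1 to compound 2 (beyond the scatter), is of similar size. Compound 2 already sits at the low end with 61%, so a further change of this kind is expected to shift the number modestly at most, downward or not beyond the scatter, a number 11 percentage points lower from compound 2 to compound 4 (beyond the scatter). For compound 4 in this assay the expected value is 50%, with a range from 25% to 75%.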

Compound 4, a percentage reported as activity, at one concentration (the size of the read-out at that concentration, not a potency): 52%
Compound 4: the middle estimate sits 2 percentage points below what was measured, within the range that was stated.
By their numbers in this assay, from the lowest: compounds 4, 2 and 3 (each within the scatter of the next, the first and the last beyond it); then compound 1.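

In this assay, nitro in place of fluoro on this aromatic carbon, para to a large group, gives a number 9 percentage points lower from compound 2 to compound 4 (within the scatter), a step that stays within the scatter. The earlier compounds shown here carried only a halogen on this ring, whereas here a single fluorine gives way to nitro, a group of 3 heavy atoms with 2 hydrogen-bond acceptors, and the number cannot be told apart from that of compound 2. At this position, then, the size of the group and the presence of acceptors do not go with any readable change across this one pair. Nothing measured here offers an explanation for this result.

As far as these compounds go, it remains open whether the same exchange on the 3-fluorophenyl ring of compound 1 would also leave the number in place. From the compounds shown here alone, it is equally open how an amine or a carboxylic acid at the position of the nitro in compound 4 would read.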